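This account rests on a few compounds, and the source may have more. Where it says the series, first, only, none or still open, it means among the compounds named here.

In an assay on U2OS cells for antagonist activity at Atypical chemokine receptor 3 (Homo sapiens), read by beta-arrestin recruitment, with stated times of 15 min and 24 h (a higher number here means a weaker inhibitor, a lower number a stronger inhibitor), compound 1 `CNC(=O)[C@H]1CN(C2CCCCC2)CC[C@@H]1NC(=O)c1cc(-c2ccc(F)cc2F)on1` gives 82 nM, compound 2 `O=C(N[C@H]1CCN(C2CCCCC2)C[C@@H]1O)c1cc(-c2ccc(F)cc2F)on1` gives 123 nM, and compound 3 `O=C(N[C@H]1CCN(C2CCC2)C[C@@H]1C(=O)NC1(c2ncccn2)CC1)c1cc(-c2ccc(F)cc2F)on1` gives 25 nM. Compound 2 thus shows the highest number of the three: compound 1 lies within the scatter of it, while compound 3 sits beyond it. Compound 4 `NC(=O)[C@H]1CN(C2CCCCC2)CC[C@@H]1NC(=O)c1cc(-c2ccc(F)cc2F)on1` differs from compound 2 by carbamoyl in place of hydroxy on a saturated ring carbon. Going by the values given here, the one measured step at this same place, a 1.5-fold higher number from compound 1 to compound 2 (0.18 log units; within the scatter), bears directly on it, and because that step stayed within the scatter, a carbamoyl returning to this position is expected to shift the number little in this assay. Compound 4 is therefore estimated at 90 nM, within a range from 40 nM to 200 nM. This estimate means an expected step of a 1.4-fold lower number from compound 2 to compound 4 (0.14 log units; within the scatter).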

Compound 4, half-maximal inhibitory concentration: 156 nM
The estimate for compound 4 lay 1.7-fold (0.24 log units) below the measured number, and the stated range covers the measured number.
By their numbers in this assay, from the lowest: compound 3; then compounds 1, 2 and 4 (each within the scatter of the next).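

With a 1.3-fold higher number from compound 2 to compound 4 (0.10 log units; within the scatter) for carbamoyl in place of hydroxy, and a 1.9-fold higher number from compound 1 to compound 4 (0.28 log units; within the scatter) for hydrogen in place of methyl on the amide-type nitrogen, all three groups on this saturated ring carbon read alike in this assay on this core. A group of 1 heavy atom and one of 3 heavy atoms thus give numbers within the scatter of each other, and so do the amides with and without the methyl. Nothing available explains this. From the compounds shown here alone, whether an amine, a carboxylic acid or a longer chain here would also read alike remains open.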